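Removing a Methyl on a Shared Core: Expected Shift

The source may hold more compounds than are shown below. What is called first, only, known or untested is meant among the compounds shown, and "the series" means these compounds.

Three compounds have been examined in a physicochemical assay for acid dissociation. Compound 1 has the structure `Cc1c(-c2noc(-c3ccc(OC(C)C)c(C#N)c3)n2)ccc2c1CCN(C(CO)CO)CC2` and in this assay compound 1 gives 8.2. Compound 2, `Cc1c(-c2noc(-c3cnc(NC(C)C)c(C#N)c3)n2)ccc2c1CCN(C(CO)CO)CC2`, differs from compound 1 in more than one place; the difference between the two cores is not broken down here. In this assay compound 2 gives 8.3, which lies within the scatter of the value of compound 1. Compound 3, `CC(C)Oc1ccc(-c2nc(-c3ccc4c(c3)CCN(C(CO)CO)CC4)no2)cc1C#N`, keeps the core of compound 1 but carries hydrogen in place of methyl on an aromatic carbon. This single change produced a number 0.40 log units lower from compound 1 to compound 3 (beyond the scatter), so the proton of compound 3 is given up somewhat more readily; in this assay compound 3 gives 7.8.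

Compound 4, `CC(C)Nc1ncc(-c2nc(-c3ccc4c(c3)CCN(C(CO)CO)CC4)no2)cc1C#N`, has not yet been measured. It stands to compound 2 as compound 3 stands to compound 1: the change is hydrogen in place of methyl on an aromatic carbon. The surroundings of the changed atom are described in exactly the same words for both pairs, so this is the same change, now made on the core of compound 2.

Because the earlier step of a number 0.40 log units lower from compound 1 to compound 3 (beyond the scatter) was modest and beyond the scatter, a step of about the same size is expected from compound 2 to compound 4, namely a number 0.40 log units lower from compound 2 to compound 4 (beyond the scatter). This expectation rests on that single earlier pair alone, so it carries real uncertainty. Compound 4 is therefore expected to give 7.9 in this assay, with the estimate ranging from 7.6 to 8.2.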

Compound 4, acid dissociation constant: 8.1
Estimate against measurement, compound 4: 0.20 log units below, and the stated range covers the measured number.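

In this assay, hydrogen in place of methyl on an aromatic carbon gave a number 0.40 log units lower from compound 1 to compound 3 (beyond the scatter), whereas the same change on the core of compound 2 gave a number 0.20 log units lower from compound 2 to compound 4 (within the scatter). This shows that a step lying beyond the usual scatter on one core need not appear beyond the scatter on another, so the result on the core of compound 1 cannot simply be taken as a firm rule for this series. Within the data shown here, it does not show that the two cores truly respond differently, as each core offers only one pair of compounds, and nothing measured here accounts for the result.

On these data alone, whether an ethyl group or a chlorine atom on the same aromatic carbon would give a step of similar size on either core remains open. As far as these compounds go, it also remains open whether this methyl-to-hydrogen change would behave in the same way on a core carrying a carboxylic acid or an amide in place of the nitrile, so how far the comparison extends beyond these four compounds is still unknown.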